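Fluoro for chloro, seen once and expected again

This account rests on a few compounds, and the source may have more. Where it says the series, first, only, none or still open, it means among the compounds named here.

Compound 1 `O=S(=O)(/C=C/c1ccc(F)cc1)Cc1ccc(Nc2ncnc3ccccc23)cc1` is a strong growth inhibitor in a functional assay on ACHN cells (Homo sapiens) (a lower number here means a stronger inhibitor of growth, a higher number a weaker inhibitor of growth), where compound 1 gives 10 nM. Compound 2 `O=S(=O)(/C=C/c1ccc(Cl)cc1)Cc1ccc(Nc2ncnc3ccccc23)cc1` differs from it only by fluoro in place of chloro on an aromatic carbon. In this assay compound 2 reaches only a limit of the measurement, > 100000 nM, and not a number. The step is therefore recorded as an at least 10000-fold lower number from compound 2 to compound 1 (4.00 log units; beyond the scatter); its size rests on (the limit of > 100000 nM in this assay, at which 1 of the 3 values shown sits).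

Compound 3 `O=S(=O)(/C=C/c1ccc(F)cc1Cl)Cc1ccc(Nc2ncnc3cc(Cl)ccc23)cc1` shares the same pattern but carries a different core; how its core differs from that of compound 2 is not broken down here. In this assay compound 3 gives 17000 nM. Compound 4 `O=S(=O)(/C=C/c1ccc(F)cc1F)Cc1ccc(Nc2ncnc3cc(Cl)ccc23)cc1` is made from compound 3 by fluoro in place of chloro on an aromatic carbon. This is the same kind of change as that from compound 2 to compound 1, not the same change: there the new fluoro sat para to a large group, here it sits ortho to a large group and meta to a fluoro group.

On the strength of the measured step, compound 4 is expected to give a lower number than compound 3, an estimated step of a 34-fold lower number from compound 3 to compound 4 (1.53 log units; beyond the scatter), with the estimate for compound 4 put at 500 nM.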

Compound 4, concentration for 50% growth inhibition: > 100000 nM
Compound 4: a limit, no number; the forecaster's own chance of this, stated with the estimate: 5%; middle value at least 200-fold (2.30 log units) away from the limit.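

In this assay compound 4 reaches only a limit of the measurement, > 100000 nM, and not a number, so the new step has a bound but no exact size: the limit of > 100000 nM in this assay, at which 2 of the 4 values shown sit. Fluoro in place of chloro gives an at least 5.8-fold higher number from compound 3 to compound 4 (0.76 log units; beyond the scatter), so the result of this swap on one core does not carry over to the other, and the direction of the change reverses: the same change on two cores in this assay, an at least 10000-fold lower number (4.00 log units; beyond the scatter) from compound 2 to compound 1 and an at least 5.8-fold higher number (0.76 log units; beyond the scatter) from compound 3 to compound 4, at least 58000-fold (4.76 log units) apart, beyond the scatter of two such steps. This does not show what turns the result around, since the two pairs differ both in the core and in where the new fluoro sits, and each pair has one compound resting on a limit.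

The compounds shown leave open how a methoxy group or a nitrile would read in place of the fluoro that enters in compound 4. They also leave open whether the 2,4-difluorophenyl group would behave differently on the core of compound 1.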